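Swapping Oxan-4-yl for Benzyl on the Ring Nitrogen

This account rests on a few compounds, and the source may have more. Where it says the series, first, only, none or still open, it means among the compounds named here.

Of the compounds shown here, three sharing one fused core have been tested in a functional assay on K562 cells (Homo sapiens) for inhibition, read by thymidine incorporation, with a stated time of 5 h; on this read-out lower numbers stand for stronger inhibition and higher numbers for weaker inhibition. Compound 1 `C(#Cc1[nH]cnc2ncnc1-2)c1ccccc1` carries a hydrogen on the five-membered ring nitrogen and gives 5.9 ug/mL. Compound 2 `C(#Cc1ncnc2c1ncn2C1CCOCC1)c1ccccc1` carries an oxan-4-yl group there and gives 3.2 ug/mL, the lowest of the three numbers. Compound 3 `Clc1nc2c(C#Cc3ccccc3)ncnc2n1C1CCOCC1` adds a chloro group to the core shared with the others; compound 3 gives 7 ug/mL. Going by the values given here, this is the only measured step, a 2.2-fold higher number from compound 2 to compound 3 (0.34 log units; beyond the scatter), and it sits at a different place from the change now in question.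

Compound 4 `C(#Cc1ncnc2c1ncn2Cc1ccccc1)c1ccccc1` differs from compound 2 in one place: benzyl in place of oxan-4-yl on an aromatic nitrogen. Among the compounds with values here, no measured step alters the group on that ring nitrogen, so nothing bears directly on this change. Compound 1 and compound 2 do differ there, but their values lie within the scatter of each other, which hints that this position tolerates variation without a marked shift in this assay.

On that basis no step beyond the scatter is expected, a 1.1-fold higher number from compound 2 to compound 4 (0.04 log units; within the scatter). Compound 4 is therefore estimated at 3.5 ug/mL, with a likely range from 1.5 ug/mL to 9 ug/mL.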

Compound 4, half-maximal inhibitory concentration: 6 ug/mL
Compound 4: middle estimate off by 1.7-fold (0.23 log units), on the low side; the range from low to high includes it.
By their numbers in this assay, from the lowest: compounds 2, 1, 4 and 3 (each within the scatter of the next, the first and the last beyond it).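

In this assay, going by these compounds alone, the step of a 1.9-fold higher number from compound 2 to compound 4 (0.27 log units; within the scatter) gives the first direct reading of a swap between two ring-bearing groups on this aromatic nitrogen, and it stays within the scatter of repeated measurements. The swap replaces a six-membered non-aromatic ring holding one oxygen with a six-membered aromatic ring of carbon only, and it removes the group's one hydrogen-bond acceptor, yet the numbers of the two compounds cannot be told apart. So, for this one pair, the difference between these two groups leaves no clear mark on this read-out, and no other measurement shown here offers an explanation for that result.

The compounds shown say nothing about very different groups on this nitrogen, such as a longer chain ending in an amine or in a carboxylic acid. They also leave open whether adding the chloro group to the shared core, which gave the step of a 2.2-fold higher number from compound 2 to compound 3 (0.34 log units; beyond the scatter), would have a similar effect with benzyl on the ring nitrogen.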